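A few compounds are considered here, and "the series" means these few. Any claim that something is new, unique, unknown or untested is made for them only; others in the source may bear on it.

Compound 1 `Cc1ccc(NC(=O)Nc2cc(-c3ccc(C(=O)O)cc3)ccc2Oc2ccccc2C(C)(C)C)cc1`, compound 2 `Cc1ccc(NC(=O)Nc2cc(-c3ccccc3C(=O)O)ccc2Nc2ccccc2C(C)(C)C)cc1` and compound 3 `Cc1ccc(NC(=O)Nc2cc(-c3ccccc3C(=O)O)ccc2N(C)c2ccccc2C(C)(C)C)cc1` share one core and were all tested in an assay on HeLa cells for inhibition of Indoleamine 2,3-dioxygenase 1 (Homo sapiens), with stated times of 1 h and 18 h; on this read-out lower numbers stand for stronger inhibition and higher numbers for weaker inhibition. Compound 1 gives only a limit of the assay, > 1000 nM. Compound 2 gives 600 nM. Compound 3 likewise gives only a limit of the assay, > 1000 nM. Among the measured compounds shown here, compound 3 thus stands at the limit of > 1000 nM in this assay, at which 2 of the 3 values shown sit, and the one measured step, an at least 1.6-fold higher number from compound 2 to compound 3 (0.22 log units; that floor lies within the scatter), is itself open-ended.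

Compound 4 `Cc1ccc(NC(=O)Nc2cc(-c3ccccc3C(=O)O)ccc2N(C)C2CCCCC2)cc1` differs from compound 3 in a single place: cyclohexyl in place of 2-(tert-butyl)phenyl on a nitrogen on an aromatic ring. For the measured compounds named here, no measured step touches this part of the molecule; the step from compound 2 to compound 3 concerns the methyl on that nitrogen, not the group beside it. Going by the values given here, there is therefore no measured step to set the size or direction of the change. Compound 4 is estimated to give 1500 nM in this assay, with a range from 500 nM to 5000 nM, the expected step that the limit leaves unreadable from compound 3 to compound 4 being read from a limit and so loosely defined.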

Compound 4, half-maximal inhibitory concentration: 14 nM
Compound 4: the middle estimate sits 110-fold (2.03 log units) above what was measured; measured number outside the range, below it.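

In this assay, among the compounds shown here, the group on the nitrogen on an aromatic ring proves to matter far more than the one earlier step at that nitrogen could suggest: cyclohexyl in place of 2-(tert-butyl)phenyl gives an at least 71-fold lower number from compound 3 to compound 4 (1.85 log units; beyond the scatter), a step read from a limit of the assay. Measured against a real number, cyclohexyl(methyl)amino in place of (2-(tert-butyl)phenyl)amino gives a 43-fold lower number from compound 2 to compound 4 (1.63 log units; beyond the scatter), so 2-(tert-butyl)phenyl is not needed for a low number in this series. Nothing shown gives a cause for this gain.

Compound 4 changes the ring and removes the tert-butyl group at once, and the compounds shown do not separate the two, as a plain phenyl or a 2-(tert-butyl)cyclohexyl group might. Going by these compounds, how cyclopentyl, an open isopropyl chain or a hydrogen in place of the methyl would read at this nitrogen also stays open.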